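A few compounds are considered here, and "the series" means these few. Any claim that something is new, unique, unknown or untested is made for them only; others in the source may bear on it.

The series rests on a shared core, a two-ring stilbene-like scaffold carrying one hydroxy on each ring in compound 1 `Oc1ccccc1/C=C/c1ccccc1O`. In a functional assay on HT-29 cells (Homo sapiens) for inhibition, read by MTT assay, with a stated time of 2 days (a lower number here means a stronger inhibitor, a higher number a weaker inhibitor), compound 1 gives 25 ug/mL. Compound 2 `Nc1ccccc1/C=C/c1ccccc1O` keeps one hydroxy and carries an amino on the other ring, and in this assay compound 2 gives 36 ug/mL. For the measured compounds named here, of the two numbers known, the one for compound 2 is the larger, but the step of a 1.4-fold higher number from compound 1 to compound 2 (0.16 log units; within the scatter) is within the scatter, so the two compounds cannot be told apart on this evidence.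

Compound 3 `COc1ccccc1/C=C/c1ccccc1O` is the next change at the same position: methoxy in place of amino on an aromatic carbon. Going by the values given here, the only measured step that bears on this place is a 1.4-fold higher number from compound 1 to compound 2 (0.16 log units; within the scatter), and it was too small to show a direction. Among the compounds with values here, no measured step shows what a methoxy does here. The expectation for compound 3 is therefore a step of a 1.1-fold higher number from compound 2 to compound 3 (0.05 log units; within the scatter), with no clear direction beyond the scatter. Compound 3 is estimated at 40 ug/mL, within a range from 18 ug/mL to 90 ug/mL.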

Compound 3, half-maximal inhibitory concentration: 23 ug/mL
Estimate against measurement, compound 3: 1.7-fold (0.24 log units) above; measured number inside the range.
By their numbers in this assay, from the lowest: compounds 3, 1 and 2 (each within the scatter of the next).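

In this assay the exchange of amino for methoxy gives a 1.6-fold lower number from compound 2 to compound 3 (0.19 log units; within the scatter) and the placing of methyl on the oxygen of the hydroxy gives a 1.1-fold lower number from compound 1 to compound 3 (0.04 log units; within the scatter) so neither step separates the compounds it joins. For the compounds shown here, this is the first look at a group without a donor at this place: methoxy enters with 0 hydrogen-bond donors where amino leaves with 1 hydrogen-bond donor, and compound 1, compound 2 and compound 3 still cannot be told apart, so across these three groups the position shows no measurable preference in this cell assay. Nothing on hand offers an explanation for this flat result.

As far as these compounds go, the three compounds span only small groups at this place, so it remains open whether a carboxylic acid, a dimethylamino group or a longer chain such as butoxy would move the number beyond the scatter. From the compounds shown here alone, the hydroxy on the other ring is the same in all three compounds, so what that group contributes, and what a methoxy or an amine would do there, also remains unknown.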